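Swapping chloro for methoxy on a bithiazole-pyrimidine nitrile

This account rests on a few compounds, and the source may have more. Where it says the series, first, only, none or still open, it means among the compounds named here.

Measured so far in a functional assay on U-87MG ATCC cells for antiproliferative activity against U-87 MG (Homo sapiens), read by MTT assay, with a stated time of 48 h, tested at 10 uM; a lower number here means a stronger effect, a higher number a weaker effect of the compound at the concentration tested:
compound 1 `COc1ccc(-c2nc(SCC(=O)c3sc(-c4ccccc4)nc3C)nc(N)c2C#N)cc1` gives 60.8%;
compound 2 `COc1ccc(-c2nc(C)c(C(=O)CSc3nc(N)c(C#N)c(-c4ccc(OC)cc4)n3)s2)cc1` gives 28.7%;
compound 3 `Cc1nc(-c2ccc(Cl)cc2)sc1C(=O)CSc1nc(N)c(C#N)c(-c2ccc(Cl)cc2)n1` gives 37.3%.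

Compound 3 stands second highest of the three; compound 2 lies within the scatter of it, while compound 1 sits higher, beyond the scatter.

Compound 4 `COc1ccc(-c2nc(SCC(=O)c3sc(-c4ccc(Cl)cc4)nc3C)nc(N)c2C#N)cc1` differs from compound 3 by methoxy in place of chloro on an aromatic carbon. For the measured compounds named here, no measured pair shows this exact exchange. Going by the values given here, the only measured step, a number 32.1 percentage points lower from compound 1 to compound 2 (beyond the scatter), concerns methoxy in place of hydrogen on the other aryl ring, so it bears only loosely. Compounds 1 and 2, which both carry the methoxy that enters here, bracket compound 3 on either side. Compound 4 is therefore expected near compound 3, with a step of a number 2.7 percentage points higher from compound 3 to compound 4 (within the scatter) not beyond the scatter, at an estimated 40% (range 22% to 58%).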

Compound 4, a percentage reported as activity, at one concentration (the size of the read-out at that concentration, not a potency): 64.5%
Compound 4: the middle estimate sits 24.5 percentage points below what was measured; measured number above the stated range.
By their numbers in this assay, from the lowest: compounds 2 and 3 (each within the scatter of the next); then compounds 1 and 4 (each within the scatter of the next).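

Compound 4 shows that the change from 4-chlorophenyl to 4-methoxyphenyl matters at this position, with a number 27.2 percentage points higher from compound 3 to compound 4 (beyond the scatter) in this assay, so chloro here gives the stronger effect when the second aryl ring carries chloro. With this 4-methoxyphenyl kept, the second ring reads a number 3.7 percentage points higher from compound 1 to compound 4 (within the scatter) for chloro in place of hydrogen and a number 35.8 percentage points higher from compound 2 to compound 4 (beyond the scatter) for chloro in place of methoxy, so of these three groups only methoxy there lowers the number. Nothing available explains these steps.

Left open is how a hydroxyl, an amine or a fluoro group would read at this position. Also open, on these data alone, is how chloro here pairs with methoxy on the second ring.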